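A few compounds are considered here, and "the series" means these few. Any claim that something is new, unique, unknown or untested is made for them only; others in the source may bear on it.

The series is followed in an in vitro ADME assay on microsomes from Gut (Homo sapiens) for metabolic stability, using NADPH; a lower number here means slower removal, a higher number faster removal of the compound. Compound 2 `CC(C)(CO)CNC(=O)c1cc2cc(C#N)ccc2n1Cc1cc(Cl)cc(Cl)c1` gives < 6 mL.min-1.g-1 in this assay, which is a limit of the assay and not a number. Compound 1 `COc1ccc(OC(F)(F)F)cc1Cn1c(C(=O)NCC(C)(C)CO)cc2cc(C#N)ccc21` gives < 6 mL.min-1.g-1, which is also a limit. Neither compound therefore has a number to set against the other, and compound 2 can only be placed at that limit.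

Compound 3 `COc1ccc(Cl)cc1Cn1c(C(=O)NCC(C)(C)CO)cc2cc(C#N)ccc21` keeps the shared core and the amide chain of compound 2 but has 5-chloro-2-methoxyphenyl in place of 3,5-dichlorophenyl on a saturated chain carbon bound to an aromatic nitrogen. The same difference, cut one bond further out, reads 3,5-dichlorobenzyl to 5-chloro-2-methoxybenzyl.

Going by the values given here, no measured step between two compounds is available for this series, so the expectation rests only on (the limit of < 6 mL.min-1.g-1 in this assay, at which 2 of the 2 values shown sit). No change beyond the scatter is expected in this assay, and removal should stay slow. The estimated step is a number no lower from compound 2 to compound 3 (the limit leaves the size open). For compound 3 the expected value is 6 mL.min-1.g-1, with an estimated range of 4 mL.min-1.g-1 to 12 mL.min-1.g-1.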

Compound 3, intrinsic clearance in microsomes: < 6 mL.min-1.g-1
Compound 3 was reported as a limit; the forecaster's own chance of this, stated with the estimate: 60%; the middle value lies on the limit itself.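

No new step can be read in this assay: the results for compound 1, compound 2 and compound 3 are all limits and not numbers, so the steps among them cannot be read. The shared reading is this: the limit of < 6 mL.min-1.g-1 in this assay, at which 3 of the 3 values shown sit.

The compounds shown leave open whether 5-chloro-2-methoxyphenyl in place of 3,5-dichlorophenyl, or chloro in place of trifluoromethoxy, changes intrinsic clearance in this assay at all.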